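Shifting fluorine on the phenoxy arm of a coumarin–pyrazole hybrid

The source may report more compounds than this note shows. Statements on the series, on what has been measured and on what is new or still open speak of the compounds shown alone.

Three compounds share one core and differ only in the fluorine pattern of the phenyl on an oxygen on an aromatic ring. Compound 1 `Cc1nn(C)c(Oc2ccccc2F)c1/C=N\CCCCCCOc1cc2oc(=O)cc(C)c2cc1Cl` carries a 2-fluorophenyl there; in a functional assay on U-87MG ATCC cells for antiproliferative activity against U-87 MG (Homo sapiens), read by MTT assay, with a stated time of 72 h (a lower number here means a stronger inhibitor, a higher number a weaker inhibitor), compound 1 gives only a limit, > 25000 nM. Compound 2 `Cc1nn(C)c(Oc2cccc(F)c2)c1/C=N\CCCCCCOc1cc2oc(=O)cc(C)c2cc1Cl` carries a 3-fluorophenyl, and compound 2 likewise gives only a limit, > 25000 nM. Among the compounds with values here, compound 3 `Cc1nn(C)c(Oc2ccc(F)cc2)c1/C=N\CCCCCCOc1cc2oc(=O)cc(C)c2cc1Cl` carries a 4-fluorophenyl and is the one compound with a number: compound 3 gives 16700 nM in this assay. The steps read as an at least 1.4-fold lower number from compound 1 to compound 3 (0.17 log units; that floor lies within the scatter) and an at least 1.4-fold lower number from compound 2 to compound 3 (0.17 log units; that floor lies within the scatter), while a step that the two limits leave unreadable from compound 1 to compound 2.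

Compound 4 `Cc1nn(C)c(Oc2cccc(F)c2F)c1/C=N\CCCCCCOc1cc2oc(=O)cc(C)c2cc1Cl` brings the change (2,3-difluorophenyl in place of 4-fluorophenyl on an oxygen on an aromatic ring). It removes the fluorine from the one pattern that gave a number and places fluorines at the two patterns that gave limits (the limit of > 25000 nM in this assay, at which 2 of the 3 values shown sit). A weaker result than compound 3 is therefore expected, most likely again at the limit. Compound 4 is expected to give about 30000 nM, within 12000 nM to 80000 nM. That is an expected step of a 1.8-fold higher number from compound 3 to compound 4 (0.25 log units; within the scatter).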

Compound 4, half-maximal inhibitory concentration: > 25000 nM
Compound 4: a limit, no number; the forecaster's own chance of this, stated with the estimate: 65%; the middle value lies beyond the limit too.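

Compound 4 gives a limit and not a number, so adding a second fluorine to the phenyl does not produce a measurable value here. The result reads as an at least 1.4-fold higher number from compound 3 to compound 4 (0.17 log units; that floor lies within the scatter), which gives only a floor, so the data cannot show whether the 2,3-difluorophenyl is truly weaker than the 4-fluorophenyl. The steps from compound 1 and compound 2 to compound 4 cannot be read, and fluorine changes on this phenyl have so far produced mostly limits: the limit of > 25000 nM in this assay, at which 3 of the 4 values shown sit.

Within the data shown here, compound 3 holds the only number, so it remains open whether any fluorine pattern on this phenyl really matters in this assay. As far as these compounds go, it also remains open whether a chlorine, a methoxy group, an amine or a carboxylic acid on this ring would give a number clearly stronger than that of compound 3.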